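Thiosemicarbazones on a shared core: methoxy to hydroxy

The compounds below may be only part of what the source reports. "The series", "measured", "known", "first", "only" and "open" are said of these compounds alone.

Measured in a functional assay on HT-29 cells (Homo sapiens) for cytotoxicity, read by sulforhodamine B assay; on this read-out lower numbers stand for stronger inhibition of growth and higher numbers for weaker inhibition of growth:
compound 1 `CC1=CC[C@@H]([C@@](C)(O)CCCC(C)(C)NC(=S)N/N=C\c2ccccc2)CC1` — 36500 nM
compound 2 `CC1=CC[C@@H]([C@@](C)(O)CCCC(C)(C)NC(=S)N/N=C\c2ccc(C)cc2)CC1` — 80400 nM
compound 3 `COc1ccc(/C=N\NC(=S)NC(C)(C)CCC[C@](C)(O)[C@@H]2CC=C(C)CC2)cc1` — 35200 nM

The three measured compounds share one core and differ only in the group carried by one aromatic carbon. Compound 3 holds the lowest of the three numbers, but its distance to compound 1 is small: a 1.0-fold lower number from compound 1 to compound 3 (0.02 log units; within the scatter). Against compound 2 the gap is wider, a 2.3-fold lower number from compound 2 to compound 3 (0.36 log units; beyond the scatter), and compound 2 is also set apart from compound 1 by a 2.2-fold higher number from compound 1 to compound 2 (0.34 log units; beyond the scatter).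

Compound 4 `CC1=CC[C@@H]([C@@](C)(O)CCCC(C)(C)NC(=S)N/N=C\c2ccc(O)cc2)CC1` has not yet been measured. It differs from compound 3 in one place: hydrogen in place of methyl on an oxygen on an aromatic ring. Among the measured compounds shown here, no measured step removes a methyl from an oxygen, so the only steps that bear on this one are those at the same aromatic carbon, where a change from hydrogen to methoxy was within the scatter and only the methyl group moved the number beyond it, and then modestly. The step from compound 3 to compound 4 is therefore expected to stay within the scatter, as a 1.1-fold lower number from compound 3 to compound 4 (0.04 log units; within the scatter). On that basis compound 4 is estimated at 32000 nM in this assay, with a range from 12000 nM to 85000 nM.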

Compound 4, concentration for total growth inhibition: 31500 nM
The estimate for compound 4 lay 1.0-fold (0.01 log units) above the measured number; the range from low to high includes it.
By their numbers in this assay, from the lowest: compounds 4, 3 and 1 (each within the scatter of the next); then compound 2.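

In this assay, the methoxy and hydroxy forms at this aromatic carbon cannot be told apart (a 1.1-fold lower number from compound 3 to compound 4 (0.05 log units; within the scatter)), so the methyl on the oxygen, the one atom that separates 4-methoxyphenyl from 4-hydroxyphenyl, shows no measurable effect on this read-out. The hydroxy compound also cannot be told apart from the compound with hydrogen at this carbon (a 1.2-fold lower number from compound 1 to compound 4 (0.06 log units; within the scatter)), but it is separated from the compound with methyl there (a 2.6-fold lower number from compound 2 to compound 4 (0.41 log units; beyond the scatter)), which leaves compound 2 as the only one of the four whose number lies beyond the scatter of the others, with hydrogen, methoxy and hydroxy forming a single cluster. Nothing available explains why methyl alone stands apart at this carbon.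

The compounds shown leave open whether an amine, a carboxylic acid or a chlorine at this aromatic carbon would join that cluster or stand apart from it, as methyl does. They also leave open whether a longer chain on the oxygen, such as ethoxy or butoxy, would stay within the scatter of methoxy and hydroxy.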